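This account rests on a few compounds, and the source may have more. Where it says the series, first, only, none or still open, it means among the compounds named here.

Compound 1 `O=c1ccoc2cc(OCc3cn(Cc4ccccc4)nn3)ccc12` carries the highest number of the three measured in a functional assay on SW480 cells (Homo sapiens) for cytotoxicity, read by MTT assay, with a stated time of 48 h (a lower number here means a stronger inhibitor, a higher number a weaker inhibitor), though its gap to compound 3 is within the scatter: compound 1 gives 42900 nM, compound 2 `Cc1cccc(Cn2cc(COc3ccc4c(=O)ccoc4c3)nn2)c1` gives 11700 nM and compound 3 `O=c1ccoc2cc(OCc3cn(Cc4ccc(Br)cc4)nn3)ccc12` gives 37500 nM. Compound 4 `O=c1ccoc2cc(OCc3cn(Cc4ccccc4Cl)nn3)ccc12` differs from compound 1 by chloro in place of hydrogen on an aromatic carbon, the chloro sitting ortho to a large group. Two measured steps from compound 1 bear on this: a 1.1-fold lower number from compound 1 to compound 3 (0.06 log units; within the scatter), and a 3.7-fold lower number from compound 1 to compound 2 (0.56 log units; beyond the scatter). Bromo in place of hydrogen thus left the number essentially unchanged, while methyl lowered it modestly; chloro in compound 4 lies nearer the bromo case. A step within the scatter, at most a slight lowering, is therefore expected: a 1.4-fold lower number from compound 1 to compound 4 (0.16 log units; within the scatter). Compound 4 is estimated at 30000 nM, with a range from 12000 nM to 70000 nM.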

Compound 4, half-maximal inhibitory concentration: 23500 nM
Compound 4: middle estimate off by 1.3-fold (0.11 log units), on the high side; measured number inside the range.
By their numbers in this assay, from the lowest: compounds 2, 4, 3 and 1 (each within the scatter of the next, the first and the last beyond it).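

In this assay, chloro ortho to a large group, turning benzyl into 2-chlorobenzyl, stays within the scatter: a 1.8-fold lower number from compound 1 to compound 4 (0.26 log units; within the scatter). Compound 4 is also not separated from either substituted neighbour, a 1.6-fold lower number from compound 3 to compound 4 (0.20 log units; within the scatter) and a 2.0-fold higher number from compound 2 to compound 4 (0.30 log units; within the scatter), although compound 1 and compound 2 are separated from each other. No measured evidence bears on this result.

Still open, as far as these compounds go, is whether an amine or a carboxylic acid at this position would give a step beyond the scatter, and what methyl would give here.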